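This account rests on a few compounds, and the source may have more. Where it says the series, first, only, none or still open, it means among the compounds named here.

Of the compounds shown here, three from this series have been measured in a functional assay on U-87MG ATCC cells for antiproliferative activity against U-87 MG (Homo sapiens), read by MTT assay, with a stated time of 48 h; on this read-out higher numbers stand for weaker inhibition and lower numbers for stronger inhibition. Compound 1 `COc1ccc(-c2nc(C)c(C(=O)CSc3nc(N)c(C#N)c(-c4ccc(Cl)cc4)n3)s2)cc1` gives 4540 nM. Compound 2 `Cc1nc(-c2ccccc2)sc1C(=O)CSc1nc(N)c(C#N)c(-c2ccc(Cl)cc2)n1`, in this assay, gives 10800 nM. Compound 3 `COc1ccc(-c2nc(SCC(=O)c3sc(-c4ccc(Cl)cc4)nc3C)nc(N)c2C#N)cc1` gives 10600 nM in this assay. Compound 1 and compound 3 are built from the same atoms joined differently; the difference between the two cores is not broken down here. Compound 2 and compound 3 give numbers within the scatter of each other, so nothing separates them in this assay.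

Compound 1 and compound 2 differ in one place: hydrogen in place of methoxy on an aromatic carbon. That change produced a 2.4-fold higher number from compound 1 to compound 2 (0.38 log units; beyond the scatter), a modest move toward weaker inhibition.

Compound 4 `Cc1nc(-c2ccc(Cl)cc2)sc1C(=O)CSc1nc(N)c(C#N)c(-c2ccccc2)n1` has not yet been measured in this assay. Within the data shown here, it differs from compound 3 by hydrogen in place of methoxy on an aromatic carbon, the same change, made on the same kind of place, as the one between compound 1 and compound 2. On one core, then, removing the methoxy cost a modest amount of potency, and compound 4 asks whether the same holds on the core of compound 3. Among the measured compounds shown here, because the measured step of a 2.4-fold higher number from compound 1 to compound 2 (0.38 log units; beyond the scatter) is the only precedent, compound 4 is expected to sit somewhat weaker than compound 3, by roughly a 1.9-fold higher number from compound 3 to compound 4 (0.28 log units; within the scatter). Compound 4 is therefore estimated at 20000 nM, with a plausible range from 8000 nM to 45000 nM, since a single precedent on a different core leaves room for the step to shrink or grow.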

Compound 4, half-maximal inhibitory concentration: 11400 nM
Estimate against measurement, compound 4: 1.8-fold (0.24 log units) above; the range from low to high includes it.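

Taking the methoxy away on this second core, the change from 4-methoxyphenyl to phenyl, gave a 1.1-fold higher number from compound 3 to compound 4 (0.03 log units; within the scatter) in this assay, so here the swap leaves no effect that can be told apart from the ordinary spread of repeat measurements. Set beside the earlier step, which did pass beyond that spread, the two results are still not far enough apart to call them different: the same change on two cores in this assay, a 2.4-fold higher number (0.38 log units; beyond the scatter) from compound 1 to compound 2 and a 1.1-fold higher number (0.03 log units; within the scatter) from compound 3 to compound 4, 2.2-fold (0.34 log units) apart, within the scatter of two such steps. This gives no sign that the core changes what the methoxy does, yet it does not prove that the change carries over either, since two steps cannot separate a small loss shared by both cores from a loss found on only one of them.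

At this place on the ring, the compounds shown hold only methoxy or hydrogen, so it remains open whether an amine, a hydroxyl group or a longer chain such as ethoxy would move the number at all, and in which direction. Also open is how the same swap would behave on a third core, as only two are shown here.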